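Morpholin-4-yl to piperidin-1-yl on the thiocarbonyl carbon

The source may hold more compounds than are shown below. What is called first, only, known or untested is meant among the compounds shown, and "the series" means these compounds.

Compound 1 `N/C(=N\NC(=S)N1CCOCC1)c1ccccn1` is the reference point of the series. For the measured compounds named here, in a functional assay on MCF7 cells (Homo sapiens) for cytotoxicity, read by MTT assay, with a stated time of 72 h, tested at 3 uM (a higher number here means more inhibition of growth at the concentration tested, a lower number less inhibition of growth), compound 1 gives 44.5%, the highest of the two numbers measured so far. Compound 2 `Cc1ccnc(/C(N)=N/NC(=S)N2CCOCC2)c1`, carrying a methyl in place of hydrogen on an aromatic carbon, gives 5.07% in this assay. Going by the values given here, the only measured step, a number 39.4 percentage points lower from compound 1 to compound 2 (beyond the scatter), is large. Compound 3 `N/C(=N\NC(=S)N1CCCCC1)c1ccccn1` differs from compound 1 by piperidin-1-yl in place of morpholin-4-yl on a thiocarbonyl carbon. Among the compounds with values here, no measured step touches the substituent on the thiocarbonyl carbon; the one known step concerns a different part of the shared core and does not bear on this change. For this assay the expectation is therefore a step no larger than the scatter in either direction, and a number 0.5 percentage points higher from compound 1 to compound 3 (within the scatter) is what is expected. Compound 3 is estimated at 45% in this assay, within 25% to 65%, the range kept wide because only a number 39.4 percentage points lower from compound 1 to compound 2 (beyond the scatter) is known and it is from elsewhere on the core.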

Compound 3, percent growth inhibition at one concentration: 38.6%
Compound 3: the middle estimate sits 6.4 percentage points above what was measured; low and high end bracket the measured number.
By their numbers in this assay, from the lowest: compound 2; then compounds 3 and 1 (each within the scatter of the next).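

In this assay, the step on the thiocarbonyl carbon reads a number 5.9 percentage points lower from compound 1 to compound 3 (within the scatter) and so stays within the scatter, which means that morpholin-4-yl and piperidin-1-yl cannot be told apart here, despite the ring oxygen and the hydrogen-bond acceptor counted for morpholin-4-yl alone. This contrasts with the methyl on an aromatic carbon, where a number 39.4 percentage points lower from compound 1 to compound 2 (beyond the scatter) lies beyond the scatter, so the two places on the shared core do not respond alike in these single steps. No measurement at hand accounts for either result.

As far as these compounds go, both groups on the thiocarbonyl carbon are six-membered non-aromatic rings, so it remains open how an open-chain dimethylamino group or a piperazin-1-yl ring would read. Also open, from the compounds shown here alone, is whether the methyl step would keep its size with piperidin-1-yl in place of morpholin-4-yl.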